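Phenyl to 2-fluorophenyl on compound 2

A few compounds are considered here, and "the series" means these few. Any claim that something is new, unique, unknown or untested is made for them only; others in the source may bear on it.

Measured so far in a functional assay on Glioma cells (Homo sapiens) for inhibition, read by MTT assay, with a stated time of 72 h (on this read-out higher numbers stand for weaker inhibition and lower numbers for stronger inhibition), on this series:
- compound 1 `C/C1=C\CC[C@@]2(C)O[C@@H]2[C@H]2OC(=O)[C@@H](CN3CCCC3)[C@@H]2C[C@H]1O` gives 5000 nM
- compound 2 `C[C@]12O[C@@H]1CC[C@@]1(C)O[C@@H]1[C@H]1OC(=O)[C@@H](CN3CCN(c4ccccc4)CC3)[C@@H]1C[C@H]2O` gives 35000 nM

Of the two numbers, the higher belongs to compound 2 at 35000 nM and the gap to compound 1 at 5000 nM lies beyond the scatter. Within the data shown here, no measured pair differs in one place only, and no single change has yet been read in this assay on this series.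

Among the measured compounds shown here, compound 3 `C[C@]12O[C@@H]1CC[C@@]1(C)O[C@@H]1[C@H]1OC(=O)[C@@H](CN3CCN(c4ccccc4F)CC3)[C@@H]1C[C@H]2O` differs from compound 2 by fluoro in place of hydrogen on an aromatic carbon as its only change, which is fluoro in place of hydrogen on an aromatic carbon, ortho to a large group, so that phenyl becomes 2-fluorophenyl.

For the measured compounds named here, no measured step bears on this change, so the expectation starts from compound 2 at 35000 nM and stays close to it. In this assay no step beyond the scatter is expected, in either direction. The estimated step is a 1.2-fold lower number from compound 2 to compound 3 (0.07 log units; within the scatter) and is expected to stay small. Compound 3 is expected at 30000 nM with an estimated range from 12000 nM to 70000 nM around that figure.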

Compound 3, half-maximal inhibitory concentration: 8000 nM
Compound 3: middle estimate off by 3.8-fold (0.57 log units), on the high side, outside the stated range (below it).
By their numbers in this assay, from the lowest: compounds 1 and 3 (each within the scatter of the next); then compound 2.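

In this assay, among these compounds, the phenyl group on compound 2 turns out to respond to a single-atom change: fluoro in place of hydrogen on an aromatic carbon, ortho to a large group, gives the first readable step on this series (a 4.4-fold lower number from compound 2 to compound 3 (0.64 log units; beyond the scatter)). The step is modest but beyond the scatter and runs toward stronger inhibition, so this aromatic carbon is not a silent place, which neither earlier compound could show on its own. Nothing measured on the fluoro group or on the compounds accounts for the step, and its origin stays unexplained.

Open, going by these compounds, is whether chloro or methoxy in place of the same hydrogen, or fluoro on another carbon of the same aromatic ring, would give a step of similar size or direction. Among the compounds shown here, compound 1 differs from compound 2 and compound 3 in more than one place, so no step to it can be read, and whether the gain from 2-fluorophenyl holds on any other amine side chain or on a different core remains undecided.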